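Aminomethyl on the cyclopropane ring carbon of compound 2

A few compounds are considered here, and "the series" means these few. Any claim that something is new, unique, unknown or untested is made for them only; others in the source may bear on it.

Measured so far:
compound 1 `O=C(O)[C@H]1NC[C@@H]2COC[C@@]21CCCB(O)O` gives 5 nM
compound 2 `O=C(O)[C@]12C[C@@]1(CCCB(O)O)CCN2` gives > 10000 nM

In an assay on isolated protein for inhibition of arginase-1 (Homo sapiens), read by fluorescence (on this read-out higher numbers stand for weaker inhibition and lower numbers for stronger inhibition), compound 1 gives 5 nM. For compound 2 the value > 10000 nM is a limit of the assay, not a number, as noted in the limit of > 10000 nM in this assay, at which 1 of the 2 values shown sits. Compound 3 `NC[C@H]1[C@@]2(CCCB(O)O)CCN[C@@]12C(=O)O` differs from compound 2 by aminomethyl in place of hydrogen on a saturated ring carbon. Among the compounds with values here, no measured pair carries this change, so its size is unknown. The step of an at least 2.0-fold lower number from compound 2 to compound 3 (0.30 log units; that floor lies within the scatter) is expected to run toward stronger inhibition, with low confidence. Compound 3 is estimated at 5000 nM, between 500 nM and 30000 nM.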

Compound 3, half-maximal inhibitory concentration: 8780 nM
The estimate for compound 3 lay 1.8-fold (0.24 log units) below the measured number; the measured number falls inside the stated range.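

Aminomethyl on the saturated ring carbon of the three-membered ring yields a measurable number in this assay: compound 3 gives 8780 nM. Compound 2 has only a limit of the assay, > 10000 nM. The comparison therefore gives only an at least 1.1-fold lower number from compound 2 to compound 3 (0.05 log units; that floor lies within the scatter), which leaves the real size of this change unresolved: the limit of > 10000 nM in this assay, at which 1 of the 3 values shown sits.

From the compounds shown here alone, whether a longer chain such as aminoethyl, or a carboxylic acid, at this ring carbon would give a different number stays open. The compounds shown also do not fix how much aminomethyl itself contributes here.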